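A few compounds are considered here, and "the series" means these few. Any claim that something is new, unique, unknown or untested is made for them only; others in the source may bear on it.

In a functional assay on C8166 cells (Homo sapiens) for cytotoxicity, read by MTT assay (on this read-out lower numbers stand for higher toxicity in this test and higher numbers for lower toxicity in this test), compound 1 (`Cc1cc(S(N)(=O)=O)ccc1NC(=O)COc1ccc(Cl)cc1NC(=O)c1ccccc1[N+](=O)[O-]`) gives 54800 nM, compound 2 (`Cc1cc(S(N)(=O)=O)ccc1NC(=O)COc1ccc(Cl)cc1NC(=O)c1cccc([N+](=O)[O-])c1`) gives 58800 nM and compound 3 (`Cc1cc(S(N)(=O)=O)ccc1NC(=O)COc1ccc(Cl)cc1NC(=O)c1cc(Br)cc(Br)c1`) gives 89700 nM. Compound 3 therefore stands with the other two, and no gap among the three values goes beyond the scatter.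

Next in the series is compound 4 (`Cc1cc(S(N)(=O)=O)ccc1NC(=O)COc1ccc(Cl)cc1NC(=O)c1ccc2ccccc2c1`), with naphthalen-2-yl in place of 3,5-dibromophenyl on a carbonyl carbon.

The three measured steps all exchange the group at this carbonyl carbon, so all of them bear on the change: a 1.1-fold higher number from compound 1 to compound 2 (0.03 log units; within the scatter), a 1.6-fold higher number from compound 1 to compound 3 (0.21 log units; within the scatter) and a 1.5-fold higher number from compound 2 to compound 3 (0.18 log units; within the scatter). None of these compounds goes against the flat picture, but none carries naphthalen-2-yl either, so the data do not cover this group directly and the range is kept wide.

With the measured exchanges as small as a 1.6-fold higher number from compound 1 to compound 3 (0.21 log units; within the scatter), no step beyond the scatter is expected in this assay, and no firm direction is expected. The step expected for the change is a 1.3-fold lower number from compound 3 to compound 4 (0.11 log units; within the scatter), which is a small move within the scatter.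

The estimated value for compound 4 is 70000 nM, with an expected range from 35000 nM to 130000 nM.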

Compound 4, half-maximal cytotoxic concentration: 37600 nM
Estimate against measurement, compound 4: 1.9-fold (0.27 log units) above; low and high end bracket the measured number.
By their numbers in this assay, from the lowest: compounds 4, 1, 2 and 3 (each within the scatter of the next, the first and the last beyond it).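

Within the data shown here, at the carbonyl carbon in this assay, the exchange of 3,5-dibromophenyl for naphthalen-2-yl gives the only step in the set that passes the scatter, a 2.4-fold lower number from compound 3 to compound 4 (0.38 log units; beyond the scatter), so the group at this position is not wholly without effect on the read-out, although the step is modest. The separation holds only against the dibromo compound, since the other two steps, a 1.6-fold lower number from compound 2 to compound 4 (0.19 log units; within the scatter) and a 1.5-fold lower number from compound 1 to compound 4 (0.16 log units; within the scatter), stay within the scatter and leave compound 4 together with the two nitrophenyl amides. Among these compounds, nothing at hand explains the one step that passes the scatter.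

As far as these compounds go, it remains open whether that step follows from the entry of naphthalen-2-yl or from the loss of the two bromine atoms, and a plain phenyl at the same carbonyl carbon would help to separate the two readings. Also open is whether a group of another kind there, such as cyclohexyl or a phenyl carrying an amine or a carboxylic acid, would move the number further than any aryl group shown so far.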